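Trifluoromethyl to Hydroxy on a Glucagon Receptor Ligand

The compounds below may be only part of what the source reports. "The series", "measured", "known", "first", "only" and "open" are said of these compounds alone.

In an assay on CHO cells for inhibition of Glucagon receptor (Homo sapiens), tested at 20 uM (on this read-out lower numbers stand for less inhibition and higher numbers for more inhibition at the one concentration tested (going by the name of the read-out)), compound 1 `CCCCCc1c(C(C)C)nc(C(C)C)c(CO)c1-c1ccc(C(F)(F)F)cc1` gives 35%. Compound 2 `CCC/C=C/c1c(C(C)C)nc(C(C)C)c(CO)c1-c1ccc(Cl)c(Cl)c1` gives 39% in this assay, a value within the scatter of that of compound 1. Compound 3 `CCCCCc1c(C(C)C)nc(C(C)C)c(CO)c1-c1ccc2ccccc2c1` gives 16% in this assay, which lies beyond the scatter below compound 1, so compound 1 stands clearly above compound 3 while it cannot be told apart from compound 2. The unmeasured compound 4 `CCCCCc1c(C(C)C)nc(C(C)C)c(CO)c1-c1ccc(O)cc1` differs from compound 1 in a single place: hydroxy in place of trifluoromethyl on an aromatic carbon. Going by the values given here, no measured pair shows this same change, so nothing among the three measured compounds speaks directly to it. Compound 4 is expected to give 20%, with a range from 5% to 38%. The estimated step is a number 15 percentage points lower from compound 1 to compound 4 (beyond the scatter), a fall beyond the scatter.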

Compound 4, a percentage reported as inhibition, at one concentration (the size of the read-out at that concentration, not a potency): 24%
Estimate against measurement, compound 4: 4 percentage points below; the measured number falls inside the stated range.
By their numbers in this assay, from the lowest: compounds 3 and 4 (each within the scatter of the next); then compounds 1 and 2 (each within the scatter of the next).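

In this assay, going by these compounds alone, hydroxy in place of trifluoromethyl gives a number 11 percentage points lower from compound 1 to compound 4 (beyond the scatter), the first step that can be read at a single place. It shows that inhibition at this aromatic carbon, para to a large group, responds to the group it carries, although compound 4 still gives 24%. Nothing available explains this fall. The compounds shown leave open how an amine or a methoxy group at this same place would read. They also leave open whether the step would hold on a core carrying a different chain.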